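A few compounds are considered here, and "the series" means these few. Any claim that something is new, unique, unknown or untested is made for them only; others in the source may bear on it.

Compound 1 `COc1cc(CNC(=S)NCC(COC(=O)C(C)(C)C)Cc2ccc(C)c(C)c2)c(Cl)cc1O` and compound 2 `COc1cc(CNC(=S)NCC(COC(=O)C(C)(C)C)Cc2ccc(C)c(C)c2)c(Br)cc1O` share one core and differ at a single aromatic carbon, where compound 1 carries chloro and compound 2 bromo. In an assay on CHO cells for displacement of a labelled ligand from transient receptor potential cation channel subfamily V member 1 (Rattus norvegicus) (on this read-out higher numbers stand for weaker inhibition and lower numbers for stronger inhibition), compound 1 gives 24.2 nM, and compound 2 gives 19.9 nM. The step of a 1.2-fold lower number from compound 1 to compound 2 (0.08 log units; within the scatter) is within the scatter. Of the two numbers, that of compound 2 is the smaller, but since the gap to compound 1 is within the scatter, no real difference between them is shown. Compound 3 `COc1cc(CNC(=S)NCC(COC(=O)C(C)(C)C)Cc2ccc(C)c(C)c2)c(I)cc1O` continues the series: iodo in place of bromo on an aromatic carbon. Among the measured compounds shown here, the only measured step that bears on this change is a 1.2-fold lower number from compound 1 to compound 2 (0.08 log units; within the scatter), a swap of one group for another at the same aromatic carbon, which stayed within the scatter. A change of the same kind is therefore expected to stay within the scatter in this assay as well, with the step from compound 2 to compound 3 expected to be a 1.2-fold lower number from compound 2 to compound 3 (0.07 log units; within the scatter). Compound 3 is estimated at 17 nM, with a range from 8 nM to 36 nM.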

Compound 3, inhibition constant: 18.9 nM
The estimate for compound 3 lay 1.1-fold (0.05 log units) below the measured number; the measured number falls inside the stated range.
By their numbers in this assay, from the lowest: compounds 3, 2 and 1 (each within the scatter of the next).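

Now that iodo has taken over from bromo, this aromatic carbon, ortho to a large group and para to a methoxy group, has carried three different halogens, and in this assay the new step stays within the scatter (a 1.1-fold lower number from compound 2 to compound 3 (0.02 log units; within the scatter)). The widest swap in the set, iodo in place of chloro, also stays within the scatter (a 1.3-fold lower number from compound 1 to compound 3 (0.11 log units; within the scatter)), so this read-out separates none of the three halogens at this position. Nothing available explains why the swaps leave the number within the scatter.

The compounds shown leave open whether this carbon needs a halogen at all, since a plain hydrogen, a methyl, an amine or a carboxylic acid here could give a very different number. They also leave open whether the same swaps would stay within the scatter on a different core.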